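This account rests on a few compounds, and the source may have more. Where it says the series, first, only, none or still open, it means among the compounds named here.

The measured compounds:
compound 1, `Cc1cc(NC(=O)CN2CCC(c3cccc[n+]3[O-])CC2)ccc1F` — 75%
compound 2, `COc1cccc(C(=O)NCN2CCC(c3cccc[n+]3[O-])CC2)c1C` — 51%
compound 3, `O=C(NCN1CCC(c2cccc[n+]2[O-])CC1)c1ccccc1` — 63%

All three share one core and were tested in a functional assay on HEK293 cells for agonist activity at D(4) dopamine receptor (Homo sapiens), read by FLIPR; on this read-out higher numbers stand for larger maximal responses and lower numbers for smaller maximal responses. On these three numbers compound 1 stands highest: compound 3 comes nearest, yet its value lies beyond the usual scatter below compound 1, and compound 2 lies further below still. Compound 4, `O=C(CN1CCC(c2cccc[n+]2[O-])CC1)Nc1cc(Cl)cc(Cl)c1`, has not been measured. It differs from compound 1 in one place: 3,5-dichlorophenyl in place of 4-fluoro-3-methylphenyl on an amide-type nitrogen. Within the data shown here, no pair of measured compounds differs by exactly this change, so no measured step shows its size. The expected step is a number 10 percentage points lower from compound 1 to compound 4 (within the scatter), a modest fall that may stay within the scatter. Compound 4 is therefore expected to reach about 65%, with a likely range from 45% to 85%.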

Compound 4, largest response reached (reported as efficacy), in percent of the reference or control that the assay uses: 68%
The estimate for compound 4 lay 3 percentage points below the measured number, within the range that was stated.
By their numbers in this assay, from the lowest: compound 2; then compounds 3, 4 and 1 (each within the scatter of the next, the first and the last beyond it).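

On an amide-type nitrogen, 3,5-dichlorophenyl in place of 4-fluoro-3-methylphenyl gives a number 7 percentage points lower from compound 1 to compound 4 (within the scatter) in this assay. This position therefore tolerates an exchange of both ring substituents, fluorine and methyl for two chlorines, at the same heavy-atom count, with no change beyond the scatter. Nothing available explains why these two groups read alike.

This single step cannot show a trend across other groups at this position. Going by these compounds, whether a cyclohexyl group or a pyridine ring on the same nitrogen would keep the response in this range remains open.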